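Adenosine series, benzyloxy to pyridinylcarbamoylmethoxy

The source may hold more compounds than are shown below. What is called first, only, known or untested is meant among the compounds shown, and "the series" means these compounds.

Measured compounds:
compound 1 `O=C(Nc1ccn(CCCN2CCC(c3ccccc3)CC2)c(=O)n1)OCc1ccccc1`, 710000 nM
compound 2 `Nc1ncnc2c1ncn2[C@@H]1O[C@H](CNCc2ccc(OCc3ccccc3)cc2)[C@@H](O)[C@H]1O`, 120000 nM

In an assay for inhibition of histone-lysine N-methyltransferase, H3 lysine-79 specific (Homo sapiens), read by scintillation counting, with a stated time of 1 h, in the presence of a further agent that is not named here (on this read-out higher numbers stand for weaker inhibition and lower numbers for stronger inhibition), compound 2 gives 120000 nM, the lower of the two numbers; compound 1 gives 710000 nM in this assay, and the gap between them lies beyond the scatter. Compound 3 `Nc1ncnc2c1ncn2[C@@H]1O[C@H](CNCc2ccc(OCC(=O)Nc3ccccn3)cc2)[C@@H](O)[C@H]1O` differs from compound 2 by (pyridin-2-yl)carbamoyl in place of phenyl on a saturated chain carbon bound to an oxygen on an aromatic ring. Within the data shown here, no step between measured compounds is known for this change, so the direction rests on the structural change alone; a step from compound 2 to compound 3 of a 1.3-fold lower number from compound 2 to compound 3 (0.12 log units; within the scatter) is expected, not beyond the scatter. Compound 3 is estimated at 90000 nM, from 20000 nM to 400000 nM.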

Compound 3, half-maximal inhibitory concentration: 54900 nM
Compound 3: middle estimate off by 1.6-fold (0.21 log units), on the high side; low and high end bracket the measured number.
By their numbers in this assay, from the lowest: compound 3; then compound 2; then compound 1.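

In this assay the change from benzyloxy to ((pyridin-2-yl)carbamoyl)methoxy gives a 2.2-fold lower number from compound 2 to compound 3 (0.34 log units; beyond the scatter) and so is a modest gain. This position on the shared core therefore accepts the larger group, and the phenyl of compound 2 is not needed to keep this level of inhibition. Nothing at hand explains the step.

Still open, as far as these compounds go, is whether the step belongs to the carbamoyl link or to the pyridin-2-yl ring. A plain phenylcarbamoyl, a carboxylic acid or a longer chain at this place would help to separate the two.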